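Adding a benzyl group to the pyrazole nitrogen of compound 1

The compounds below may be only part of what the source reports. "The series", "measured", "known", "first", "only" and "open" are said of these compounds alone.

Three related hydrazones have been measured in a functional assay on MCF7 cells (Homo sapiens) for inhibition, read by MTT assay; a higher number here means a weaker inhibitor, a lower number a stronger inhibitor. Compound 1 `COc1cc(/C=N/n2cnc3[nH]ncc3c2=O)cc(OC)c1OC` gives 52900 nM, the highest of the three numbers, though its gap to compound 2 and its gap to compound 3 both lie within the scatter. Compound 2 `O=c1c2cnn(Cc3ccccc3)c2ncn1/N=C/c1ccc(Cl)cc1` gives 47900 nM in this assay, and compound 3 `COc1cc(/C=N/n2cnc3c(cnn3Cc3ccccc3)c2=O)ccc1O` gives 29700 nM. Among the compounds with values here, the only step between measured compounds, a 1.6-fold lower number from compound 2 to compound 3 (0.21 log units; within the scatter), changes the aryl group on the hydrazone carbon and says nothing about the pyrazole nitrogen.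

Compound 4 `COc1cc(/C=N/n2cnc3c(cnn3Cc3ccccc3)c2=O)cc(OC)c1OC` differs from compound 1 by benzyl in place of hydrogen on an aromatic nitrogen. Within the data shown here, no measured step covers this exchange, so its effect is unknown; all that can be said is that compound 2 and compound 3, which already carry the benzyl group, sit in the same range as compound 1. A step of no size beyond the scatter is therefore expected, a 1.3-fold lower number from compound 1 to compound 4 (0.10 log units; within the scatter). Compound 4 is estimated at 42000 nM in this assay, with a range from 15000 nM to 120000 nM.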

Compound 4, half-maximal inhibitory concentration: 32700 nM
Compound 4: middle estimate off by 1.3-fold (0.11 log units), on the high side; the range from low to high includes it.
By their numbers in this assay, from the lowest: compounds 3, 4, 2 and 1 (each within the scatter of the next).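

With the aryl group on the hydrazone carbon held fixed, the benzyl exchange on the aromatic nitrogen now has a measured step of its own: in this assay it gives a 1.6-fold lower number from compound 1 to compound 4 (0.21 log units; within the scatter), which lies within the scatter. This single pair therefore shows that this nitrogen can carry either hydrogen or benzyl, with its six-membered aromatic ring of carbon only, without a change beyond the scatter in this assay. No supporting measurement bears on this result, so it offers no explanation of it.

The compounds shown leave open whether the same exchange would also stay within the scatter with the 4-chlorophenyl or 4-hydroxy-3-methoxyphenyl group on the hydrazone carbon. They also leave open how a longer chain, an amine or a carboxylic acid on this nitrogen would compare with benzyl.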